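A Dichlorophenyl Swap on a Sulfonyl Sulfur

A few compounds are considered here, and "the series" means these few. Any claim that something is new, unique, unknown or untested is made for them only; others in the source may bear on it.

Compound 1 `CC1CCN(C2CCN(S(=O)(=O)c3ccc(Cl)nc3)CC2)CC1` and compound 2 `CC1CCN(C2CCN(S(=O)(=O)c3cccc(Br)c3)CC2)CC1` have a shared core and differ in the group on the sulfonyl sulfur. In an ADME assay on HCT-116 cells (Homo sapiens) for cytotoxicity, read by CellTiter-Glo, with a stated time of 72 h (on this read-out higher numbers stand for weaker inhibition and lower numbers for stronger inhibition), compound 1 gives only a limit, > 10000 nM. Compound 2 also gives only a limit, > 5000 nM, so it has no exact place on the numbers. Compound 3 `CC1CCN(C2CCN(S(=O)(=O)c3ccc(Cl)c(Cl)c3)CC2)CC1` differs from compound 2 by one change: 3,4-dichlorophenyl in place of 3-bromophenyl on a sulfonyl sulfur. Going by the values given here, the only measured step that bears on this, a step that the two limits leave unreadable from compound 1 to compound 2, changed the group at that same place and offers no size to carry over. Resting on the limit of compound 2 at > 5000 nM, no step beyond the usual scatter is expected in this assay. The expected step is a step that the limit leaves unreadable from compound 2 to compound 3. For compound 3 the estimated value is 7000 nM, with an expected range from 3000 nM to 15000 nM.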

Compound 3, half-maximal inhibitory concentration: > 5000 nM
Compound 3 was reported as a limit; the forecaster's own chance of this, stated with the estimate: 80%; the middle value does not contradict the limit.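

Going by these compounds alone, compound 1, compound 2 and compound 3 all stand only as limits in this assay, and no step among them can be read. The compounds shown leave open how the 6-chloropyridin-3-yl, 3-bromophenyl and 3,4-dichlorophenyl groups on the sulfonyl sulfur compare on exact values.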